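The source may report more compounds than this note shows. Statements on the series, on what has been measured and on what is new or still open speak of the compounds shown alone.

Measured in an ADME assay on Vero cells (Chlorocebus sabaeus) for cytotoxicity, read by MTT assay, with a stated time of 48 h; a higher number here means a weaker inhibitor, a lower number a stronger inhibitor:
compound 1 `Cc1cccc(C(=O)OC2CCC(CN3CCN(c4cc(=O)c5cc(C(F)(F)F)cc([N+](=O)[O-])c5s4)CC3)CC2)c1`: > 64 ug/mL (a limit)
compound 2 `CC(C)S(=O)(=O)OC1CCC(CN2CCN(c3cc(=O)c4cc(C(F)(F)F)cc([N+](=O)[O-])c4s3)CC2)CC1`: > 64 ug/mL (a limit)

Compound 2 has no numerical value, only a limit of > 64 ug/mL. The evidence so far comes down to the limit of > 64 ug/mL in this assay, at which 2 of the 2 values shown sit. Among the compounds with values here, the one measured step is a step that the two limits leave unreadable from compound 1 to compound 2, so it provides no size to carry forward.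

Compound 3 `CS(=O)(=O)NC1CCC(CN2CCN(c3cc(=O)c4cc(C(F)(F)F)cc([N+](=O)[O-])c4s3)CC2)CC1` carries methanesulfonamido in place of (isopropylsulfonyl)oxy on a saturated ring carbon. Within the data shown here, with a step that the two limits leave unreadable from compound 1 to compound 2 as the only guide, no step beyond the scatter is expected in this assay, and no direction can be assigned. The expected step is a number no higher from compound 2 to compound 3 (the limit leaves the size open). A reading at the same limit is the most likely outcome. For compound 3 the estimated value is 64 ug/mL, with an expected range from 30 ug/mL to 128 ug/mL.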

Compound 3, half-maximal inhibitory concentration: 48.5 ug/mL
The estimate for compound 3 lay 1.3-fold (0.12 log units) above the measured number, within the range that was stated.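

In this assay, within the data shown here, compound 3 gives 48.5 ug/mL, the only number among the values shown, so with methanesulfonamido on this saturated ring carbon the series yields a readable value for the first time. Methanesulfonamido in place of (isopropylsulfonyl)oxy gives an at least 1.3-fold lower number from compound 2 to compound 3 (0.12 log units; that floor lies within the scatter), and the same group in place of ((3-methylphenyl)carbonyl)oxy gives an at least 1.3-fold lower number from compound 1 to compound 3 (0.12 log units; that floor lies within the scatter); both are floors, and the true sizes remain open. The readings for the other two compounds remain limits: the limit of > 64 ug/mL in this assay, at which 2 of the 3 values shown sit.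

The compounds shown do not separate the effect of the nitrogen link from that of the smaller methyl group on the sulfonyl. Ethanesulfonamido, acetamido or a free amine on the same ring carbon would address that question.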